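One Added Methyl on a Potent Ester

The source may report more compounds than this note shows. Statements on the series, on what has been measured and on what is new or still open speak of the compounds shown alone.

In a functional assay on MCF7 cells (Homo sapiens) for cytotoxicity, read by MTT assay, with a stated time of 72 h (a higher number here means a weaker inhibitor, a lower number a stronger inhibitor), compound 1 (`CCOC(=O)c1sc2ccccc2c1Nc1cc(OC)c(OC)c(OC)c1`) gives 6390 nM and compound 2 (`COC(=O)c1sc2cc(C)ccc2c1Nc1cc(OC)c(OC)c(OC)c1`) gives 1.2 nM (the lower number of the two, by a gap far beyond the scatter). Compound 3 (`CCOC(=O)c1sc2cc(C)ccc2c1Nc1cc(OC)c(OC)c(OC)c1`) differs from compound 2 by methyl in place of hydrogen on a saturated chain carbon bound to an oxygen next to a carbonyl group (methoxycarbonyl to ethoxycarbonyl). Among the compounds with values here, no measured step isolates this change, but compound 1 (6390 nM) also carries ethoxycarbonyl, so a moderate rise towards weaker inhibition is expected in this assay and not a step within the scatter. The estimated step is a 17-fold higher number from compound 2 to compound 3 (1.22 log units; beyond the scatter) (towards a higher number). For compound 3 the expected value is 20 nM (estimated range 1.5 nM to 600 nM).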

Compound 3, half-maximal inhibitory concentration: 9 nM
The estimate for compound 3 lay 2.2-fold (0.35 log units) above the measured number, and the stated range covers the measured number.
By their numbers in this assay, from the lowest: compound 2; then compound 3; then compound 1.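

In this assay, extending methoxycarbonyl to ethoxycarbonyl gives a modest but real loss (a 7.5-fold higher number from compound 2 to compound 3 (0.88 log units; beyond the scatter)), so this ester position responds to one added methyl on a saturated chain carbon. Even so, ethoxycarbonyl is compatible with strong inhibition: methyl in place of hydrogen on an aromatic carbon gives a much larger change (a 710-fold lower number from compound 1 to compound 3 (2.85 log units; beyond the scatter)). Nothing available explains either step. On these data alone, whether a propyl ester, an amide or a carboxylic acid at this position would continue the trend remains open.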